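A few compounds are considered here, and "the series" means these few. Any claim that something is new, unique, unknown or untested is made for them only; others in the source may bear on it.

Compound 3 `Cc1ccc(-c2nc(SCc3cn(CC(=O)NC(=O)Nc4ccccn4)nn3)nc(Nc3ccc(C(C)C)cc3)c2C#N)cc1` gives 7450 nM in a functional assay on ECa-109 cells (Homo sapiens) for inhibition, read by MTT assay, with a stated time of 72 h (a lower number here means a stronger inhibitor, a higher number a weaker inhibitor), the highest of the two numbers shown; compound 1 `CC(C)c1ccc(Nc2nc(SCc3cn(CC(=O)NC(=O)Nc4ccccn4)nn3)nc(-c3ccc(C(C)C)cc3)c2C#N)cc1` gives 2490 nM in this assay, and a 3.0-fold higher number from compound 1 to compound 3 (0.48 log units; beyond the scatter). In this assay compound 2 `COc1cc(-c2nc(SCc3cn(CC(=O)NC(=O)Nc4ccccn4)nn3)nc(Nc3ccc(C(C)C)cc3)c2C#N)cc(OC)c1OC` gives > 64000 nM, a limit of the assay and not a number. That limit sets an at least 25-fold higher number from compound 1 to compound 2 (1.40 log units; beyond the scatter) and an at least 8.5-fold lower number from compound 2 to compound 3 (0.93 log units; beyond the scatter). Compound 4 `Cc1ccc(-c2nc(SCc3cn(CC(=O)NC(=O)Nc4ccccn4)nn3)nc(Nc3cccc(Cl)c3)c2C#N)cc1` differs from compound 3 by 3-chlorophenyl in place of 4-isopropylphenyl on a nitrogen on an aromatic ring. Every measured step changes the aryl on the aromatic carbon, none the aryl on the nitrogen, so they bear only loosely on this change; a modest step of uncertain direction is expected, a 1.3-fold higher number from compound 3 to compound 4 (0.13 log units; within the scatter). Compound 4 is therefore estimated at 10000 nM in this assay, within 3000 nM to 40000 nM.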

Compound 4, half-maximal inhibitory concentration: 25600 nM
Compound 4: middle estimate off by 2.6-fold (0.41 log units), on the low side, and the stated range covers the measured number.
By their numbers in this assay, from the lowest: compound 1; then compound 3; then compound 4. At a limit, above all of these: compound 2.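

In this assay, the aryl on the nitrogen also moves the number: 3-chlorophenyl in place of 4-isopropylphenyl gives a 3.4-fold higher number from compound 3 to compound 4 (0.54 log units; beyond the scatter) and is the first change shown at this position. Sensitivity in the series therefore no longer rests only on the aryl on the aromatic carbon, and here the change leaves compound 4 weaker than compound 3. Nothing measured here accounts for this step.

This single step cannot separate losing the isopropyl group from gaining the chlorine. Going by these compounds, how a methoxy group or an amine on this phenyl ring would fare remains open.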